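The compounds below may be only part of what the source reports. "The series", "measured", "known", "first", "only" and "open" are said of these compounds alone.

In a functional assay on SW982 cells (Homo sapiens) for inhibition, read by MTT assay, with a stated time of 72 h (a higher number here means a weaker inhibitor, a lower number a stronger inhibitor), compound 1 `COc1cc(OC)c(OC)cc1/C=C/C(=O)c1ccc(Cl)cc1` gives 58500 nM and compound 2 `COc1cc(OC)c(OC)cc1/C=C/C(=O)c1cc(Cc2ccccc2)cc(Cc2ccccc2)c1` gives 69900 nM, two numbers within the scatter of each other. Compound 3 `COc1cc(OC)c(OC)cc1/C=C/C(=O)c1ccc(O)cc1O` keeps the shared core but has 2,4-dihydroxyphenyl in place of 4-chlorophenyl on a carbonyl carbon. Among the compounds with values here, no measured pair isolates this change, so the guide is indirect. Compound 2, with a different group at that place, gives 69900 nM, so only a small change is expected. The estimated step of a 1.7-fold lower number from compound 1 to compound 3 (0.22 log units; within the scatter) leans slightly towards a stronger inhibitor and stays within the scatter. For compound 3 the expected value is 35000 nM, with an estimated range from 12000 nM to 90000 nM.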

Compound 3, half-maximal inhibitory concentration: 32400 nM
Compound 3: middle estimate off by 1.1-fold (0.03 log units), on the high side; the measured number falls inside the stated range.
By their numbers in this assay, from the lowest: compounds 3, 1 and 2 (each within the scatter of the next, the first and the last beyond it).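

Within the data shown here, putting 2,4-dihydroxyphenyl in place of 4-chlorophenyl on a carbonyl carbon gives a 1.8-fold lower number from compound 1 to compound 3 (0.26 log units; within the scatter) in this assay, the first direct step at this position. The entering group has two hydrogen-bond donors and the leaving group has none, yet the step stays within the scatter. No measurement here explains this result. Still open, as far as these compounds go, is whether an amine or a carboxylic acid on this ring would give a step beyond the scatter, and whether a single hydroxy group would behave like the two present in compound 3 .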